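Urea versus amide at the carbonyl of the series

This account rests on a few compounds, and the source may have more. Where it says the series, first, only, none or still open, it means among the compounds named here.

Measured compounds:
- compound 1 `O=C(Nc1cccc(-n2cc(-c3ccncc3)c(-c3ccc(Cl)c(O)c3)n2)c1)Nc1cccc(C(F)(F)F)c1`: > 32500 nM in a functional assay on A549 cells (Homo sapiens) for inhibition, read by sulforhodamine B assay, with a stated time of 48 h; on this read-out lower numbers stand for stronger inhibition of growth and higher numbers for weaker inhibition of growth
- compound 2 `COc1cc(-c2nn(-c3cccc(NC(=O)c4cccc(C(F)(F)F)c4)c3)cc2-c2ccncc2)ccc1Cl`: > 50000 nM

Compound 1 reaches only a limit of this assay, (the limit of > 32500 nM in this assay, at which 1 of the 2 values shown sits). Compound 2 likewise reaches only a limit, (the limit of > 50000 nM in this assay, at which 1 of the 2 values shown sits). Neither value is a number, so no order between compound 1 and compound 2 can be read from them; both sit at the weak end of what this assay reports.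

Compound 3 `COc1cc(-c2nn(-c3cccc(NC(=O)Nc4cccc(C(F)(F)F)c4)c3)cc2-c2ccncc2)ccc1Cl` has not been measured. It differs from compound 2 in one place: (3-(trifluoromethyl)phenyl)amino in place of 3-(trifluoromethyl)phenyl on a carbonyl carbon. For the measured compounds named here, no pair of measured compounds differs only at that point, so the size of the step is not known from the data. Compound 1 carries the same urea linkage and still gives only a limit, > 32500 nM, which gives no sign that the urea by itself brings the value into the measurable range.

The step from compound 2 to compound 3 is therefore expected to be a number no higher from compound 2 to compound 3 (the limit leaves the size open), with no movement beyond the scatter. Compound 3 is estimated at 50000 nM, between 20000 nM and 120000 nM, most probably again reported only as a limit.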

Compound 3, concentration for total growth inhibition: > 50000 nM
Compound 3 gave a limit, no number; the forecaster's own chance of this, stated with the estimate: 80%; the middle value lies on the limit itself.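

In this assay compound 3 gives > 50000 nM, a limit and not a number. The steps to compound 3 from compound 2 and from compound 1 therefore cannot be read. The compounds shown leave open whether the urea in place of the amide, or methyl in place of hydrogen on the aromatic-ring oxygen, changes growth inhibition at all.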